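The compounds below may be only part of what the source reports. "The series", "measured", "known", "first", "only" and "open" are said of these compounds alone.

Of the compounds shown here, three built on a shared core have been measured, and a fourth is waiting for its number. Within the data shown here, compound 2 `C=C1C(=O)[C@]23C[C@@]1(O)CC[C@H]2c1ccc(O)c(C)c1[C@@H]3Cn1cc(-c2ccc(F)cc2)nn1` carries a hydroxy group on its aromatic ring; in a functional assay on HL-60 cells (Homo sapiens) for cytotoxicity, read by MTT assay, with a stated time of 4 days (a lower number here means a stronger inhibitor, a higher number a weaker inhibitor), compound 2 gives 660 nM, the only plain number among the three. Compound 3 `C=C1C[C@]23C[C@@]1(O)CC[C@H]2c1ccc(O)c(C)c1[C@@H]3Cn1cc(-c2ccc(Br)cc2)nn1` has a related core, but the difference between the two cores is not broken down here. In this assay compound 3 reaches only a limit, > 20000 nM. Compound 1 `C=C1C[C@]23C[C@@]1(O)CC[C@H]2c1ccc(OS(=O)(=O)c2ccc(C)cc2)c(C)c1[C@@H]3Cn1cc(-c2ccc(Br)cc2)nn1` arises from compound 3 through the change ((4-methylphenyl)sulfonyl in place of hydrogen on an oxygen on an aromatic ring). In this assay compound 1 likewise reaches only a limit, > 20000 nM. The step that the two limits leave unreadable from compound 3 to compound 1 therefore cannot be read, as both values sit at the limit of > 20000 nM in this assay, at which 2 of the 3 values shown sit. Compound 4 `C=C1C(=O)[C@]23C[C@@]1(O)CC[C@H]2c1ccc(OS(=O)(=O)c2ccc(C)cc2)c(C)c1[C@@H]3Cn1cc(-c2ccc(F)cc2)nn1` arises from compound 2 by the same change, ((4-methylphenyl)sulfonyl in place of hydrogen on an oxygen on an aromatic ring). Among the measured compounds shown here, no measured pair shows how large this step is. The step of a 3.8-fold higher number from compound 2 to compound 4 (0.58 log units; beyond the scatter) is an estimate that leans toward weakening, resting on the step that the two limits leave unreadable from compound 3 to compound 1. The estimate also rests on the plain number of compound 2, 660 nM. Compound 4 is therefore expected to give 2500 nM, within a range from 500 nM to 20000 nM.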

Compound 4, half-maximal inhibitory concentration: 1290 nM
Compound 4: the middle estimate sits 1.9-fold (0.29 log units) above what was measured; the measured number falls inside the stated range.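

On the core of compound 2, putting (4-methylphenyl)sulfonyl in place of hydrogen on the oxygen on the aromatic ring gives a 2.0-fold higher number from compound 2 to compound 4 (0.29 log units; within the scatter) in this assay, so this measurement does not tell the two compounds apart. On the core of compound 3, the same change leaves no size that can be read, since both compounds of that pair give only a limit of the assay, not a number: the limit of > 20000 nM in this assay, at which 2 of the 4 values shown sit. The change can therefore be sized on one core only, and this single pair does not show that it would behave the same way on the other core.

The compounds shown leave open what other groups on that oxygen would do, such as a plain methyl, an acetyl or a longer chain ending in an amine. Among these compounds, they also include no pair that separates the carbonyl of compound 2 from its 4-fluorophenyl group, so neither part can be tested alone against the core of compound 3.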